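Methyl for trifluoromethyl on the aryl of compound 1

A few compounds are considered here, and "the series" means these few. Any claim that something is new, unique, unknown or untested is made for them only; others in the source may bear on it.

Measured compounds:
compound 1 `O=C1C=CC(OCC(F)(F)F)N1c1ccc(C(F)(F)F)cc1` — 36200 nM
compound 2 `CC(C)NC1CC(=O)N(c2ccc(F)c(Cl)c2)C1OCC(F)(F)F` — 6610 nM
compound 3 `O=C1C=CC(OCC(F)(F)F)N1c1cc(F)cc(F)c1` — 8460 nM

In a functional assay on HeLa cells (Homo sapiens) for inhibition (on this read-out higher numbers stand for weaker inhibition and lower numbers for stronger inhibition), compound 1 gives 36200 nM, the highest number of the three. The nearest is compound 3, with a lower number, and the furthest is compound 2; both gaps lie beyond the scatter, so compound 1 is the weakest inhibitor of those measured.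

Compound 4 `Cc1ccc(N2C(=O)C=CC2OCC(F)(F)F)cc1` differs from compound 1 by methyl in place of trifluoromethyl on an aromatic carbon. Going by the values given here, no pair of measured compounds shows this same change, so its size is not known from the series. Compound 4 is expected to give 22000 nM in this assay, with a range of 7000 nM to 65000 nM. The estimated step of a 1.6-fold lower number from compound 1 to compound 4 (0.22 log units; within the scatter) is a small shift toward stronger inhibition, not clearly beyond the scatter.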

Compound 4, half-maximal inhibitory concentration: 9380 nM
Estimate against measurement, compound 4: 2.3-fold (0.37 log units) above; low and high end bracket the measured number.
By their numbers in this assay, from the lowest: compounds 2, 3 and 4 (each within the scatter of the next); then compound 1.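

In this assay, going by these compounds alone, methyl in place of trifluoromethyl on an aromatic carbon para to a large group gives a 3.9-fold lower number from compound 1 to compound 4 (0.59 log units; beyond the scatter) and is the first single-place step. This position therefore responds to the group it carries, and methyl gives the stronger inhibition of the two groups. Nothing available explains the step.

The trend rests on this one pair, so a methoxy group, a nitrile or an amine at this position could fit it or break it. From the compounds shown here alone, whether the same change gives a similar step on another aryl pattern also remains open.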